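Swapping the amide ring on a shared core

A few compounds are considered here, and "the series" means these few. Any claim that something is new, unique, unknown or untested is made for them only; others in the source may bear on it.

Compound 1 `CCN(C)C(=O)[C@H]1C[C@@H](C(=O)N2CCC[C@H]2C#N)N[C@H]1C` and compound 2 `C[C@@H]1N[C@H](C(=O)N2CCC[C@H]2C#N)C[C@@H]1C(=O)N1CCCC1` share one core and differ only in the amine on a carbonyl carbon. In an assay on the whole organism (plasma, strain Sprague-Dawley) for inhibition of Dipeptidyl peptidase 4 (Rattus norvegicus), with a stated time of 6 h, at a dose of 1 mg/kg by the oral route (a lower number here means less inhibition, a higher number more inhibition at the dose given (going by the name of the read-out)), compound 1 gives 92%, and compound 2 gives 94%, so compound 2 holds the higher of the two numbers shown, though the step of a number 2 percentage points higher from compound 1 to compound 2 (within the scatter) is within the scatter and no order between them can be claimed.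

Compound 3 `C[C@@H]1N[C@H](C(=O)N2CCC[C@H]2C#N)C[C@@H]1C(=O)N1CCSCC1` keeps everything except that same amide amine: thiomorpholin-4-yl in place of pyrrolidin-1-yl on a carbonyl carbon. Going by the values given here, the only measured step that touches this position, a number 2 percentage points higher from compound 1 to compound 2 (within the scatter), changed the amine on the same carbonyl carbon and moved the read-out within the scatter. On that basis, the step of a number 6 percentage points lower from compound 2 to compound 3 (within the scatter) is expected to stay within the scatter too, with perhaps a slight drift down as the ring grows. Compound 3 is therefore estimated at 88%, in a range from 72% to 96%.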

Compound 3, a percentage reported as inhibition, in the whole organism at one dose (the size of the read-out at that dose, not a potency): 92%
Compound 3: middle estimate off by 4 percentage points, on the low side; the measured number falls inside the stated range.
By their numbers in this assay, from the lowest: compounds 1, 3 and 2 (each within the scatter of the next).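

In this assay, the amine on this carbonyl carbon can now be a six-membered ring holding sulfur as well as a five-membered ring or an open-chain amine: the step of a number 2 percentage points lower from compound 2 to compound 3 (within the scatter) and the step of no change at the digits printed from compound 1 to compound 3 (within the scatter) both leave the read-out indistinguishable. Thiomorpholin-4-yl enters with 6 heavy atoms and 1 hydrogen-bond acceptor where pyrrolidin-1-yl has 5 and 0, and this difference in the counts comes with no measurable separation at this single dose and time. Nothing available here explains why the read-out holds across these three amines.

On these data alone, whether an amine bearing a carboxylic acid or a longer chain would keep the read-out at this level remains open. As far as these compounds go, it is also open whether these three compounds would separate at a smaller dose or a later time.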